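From a Hexyl Chain to an Acetyl Group

This account rests on a few compounds, and the source may have more. Where it says the series, first, only, none or still open, it means among the compounds named here.

compound 1, `CCCCCc1ccc(NC(=O)N[C@@H](C)c2ccccc2)cc1`: 98%
compound 2, `CCCCCCc1ccc(NC(=O)N[C@@H](C)c2ccccc2)cc1`: 100%

Both readings come from an ADME assay on the whole organism with Oryza sativa as the target, tested at 1 uM; on this read-out lower numbers stand for a stronger effect and higher numbers for a weaker effect at the one concentration tested. Compound 2 stands highest of the two numbers, and the nearest reading is that of compound 1, a difference within the scatter. Among the compounds with values here, the single measured step, a number 2 percentage points higher from compound 1 to compound 2 (within the scatter), is a change on the saturated chain only and does not separate the two compounds beyond the scatter.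

Compound 3, `CC(=O)c1ccc(NC(=O)N[C@@H](C)c2ccccc2)cc1`, is still to be measured in this assay. It differs from compound 2 in one place: acetyl in place of hexyl on an aromatic carbon. Within the data shown here, no measured step touches a change of this kind, so the data give no guide to its direction or size. The expected step is a number 10 percentage points lower from compound 2 to compound 3 (within the scatter), a modest shift toward a stronger effect with wide uncertainty. Compound 3 is therefore estimated at 90%, with a range from 60% to 105%.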

Compound 3, a percentage reported as activity, at one concentration (the size of the read-out at that concentration, not a potency): 99%
For compound 3 the middle estimate is 9 percentage points below the measured one; low and high end bracket the measured number.
By their numbers in this assay, from the lowest: compounds 1, 3 and 2 (each within the scatter of the next).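

The earlier compounds shown here showed only a change within the saturated chain, whereas compound 3 replaces the whole chain on the aromatic carbon, para to a large group, with acetyl, which brings a hydrogen-bond acceptor and fewer heavy atoms. In this assay, this exchange gives a number 1 percentage points lower from compound 2 to compound 3 (within the scatter), and the comparison with the shorter chain gives a number 1 percentage points higher from compound 1 to compound 3 (within the scatter). Neither the chain length nor the exchange of a chain for acetyl therefore separates these compounds at this position. Nothing available bears on why the read-out stays within the scatter across this exchange.

Going by these compounds, it remains open whether any group at this place, such as an amine or a carboxylic acid, would move the read-out beyond the scatter. On these data alone, whether a change elsewhere on the shared core would do so also remains open.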